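Dichlorophenyl amide in the D(4) series

The compounds below may be only part of what the source reports. "The series", "measured", "known", "first", "only" and "open" are said of these compounds alone.

Compounds measured so far:
compound 1, `Cc1cc(C)cc(NC(=O)CN2CCC(c3cccc[n+]3[O-])CC2)c1`: 52 nM
compound 2, `O=C(CN1CCC(c2cccc[n+]2[O-])CC1)NC1CCCCC1`: 294 nM

Of the two numbers in a functional assay on HEK293 cells for agonist activity at D(4) dopamine receptor (Homo sapiens), read by FLIPR (on this read-out lower numbers stand for an effect already at smaller amounts and higher numbers for an effect only at larger amounts of compound), compound 2 holds the highest; its nearest neighbour is compound 1, and the step of a 5.7-fold higher number from compound 1 to compound 2 (0.75 log units; beyond the scatter) lies beyond the scatter. Compound 3, `O=C(CN1CCC(c2cccc[n+]2[O-])CC1)Nc1cccc(Cl)c1Cl`, differs from compound 2 by 2,3-dichlorophenyl in place of cyclohexyl on an amide-type nitrogen. For the measured compounds named here, the only measured step that bears on this change runs the other way, from an aryl to cyclohexyl on that nitrogen, and was modest. Compound 3 is therefore expected to give a lower number than compound 2, a step of about a 4.2-fold lower number from compound 2 to compound 3 (0.62 log units; beyond the scatter), with an estimated 70 nM (range 20 nM to 250 nM).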

Compound 3, half-maximal effective concentration: 180 nM
Compound 3: middle estimate off by 2.6-fold (0.41 log units), on the low side, within the range that was stated.
By their numbers in this assay, from the lowest: compound 1; then compounds 3 and 2 (each within the scatter of the next).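

In this assay, putting an aromatic ring on the amide-type nitrogen does not by itself separate the compounds: the step of a 1.6-fold lower number from compound 2 to compound 3 (0.21 log units; within the scatter) leaves the two without an order. The choice of aryl group does matter between these compounds, as 2,3-dichlorophenyl in place of 3,5-dimethylphenyl gives a 3.5-fold higher number from compound 1 to compound 3 (0.54 log units; beyond the scatter) on the shared core. Nothing available explains either step.
From the compounds shown here alone, it remains open whether the two chlorine atoms or the pattern of substitution accounts for the gap to compound 1. A benzyl group or a methoxyphenyl group on that nitrogen also remains untested among the compounds shown here.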